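This account rests on a few compounds, and the source may have more. Where it says the series, first, only, none or still open, it means among the compounds named here.

In a functional assay on KG-1 cells (Homo sapiens) for inhibition, read by MTT assay, with a stated time of 48 h (a higher number here means a weaker inhibitor, a lower number a stronger inhibitor), compound 1 `O=C(CCCCCCCOc1cccc(-c2nc3ccc(-c4nc5ccccc5[nH]4)cc3[nH]2)c1)NO` gives 1600 nM and compound 2 `O=C(CCCCCCOc1cccc(-c2nc3ccccc3[nH]2)c1)NO` gives 190 nM as the lower number of the two, a gap beyond the scatter. Compound 2 is therefore the stronger inhibitor of this pair. Compound 3 `O=C(CCCCCCCOc1cccc(-c2nc3ccccc3[nH]2)c1)NO` has not yet been measured. Going by the values given here, it carries (hydroxycarbamoyl)methyl in place of hydroxycarbamoyl on a saturated chain carbon, six bonds along the chain from an oxygen on an aromatic ring, the single change from compound 2 counted as (hydroxycarbamoyl)methyl in place of hydroxycarbamoyl on a saturated chain carbon, six bonds along the chain from an oxygen on an aromatic ring in these notes. Among the compounds with values here, no pair of measured compounds isolates this change, so the series offers no direct precedent. No step beyond the scatter is expected in this assay and neither direction is favoured. The expected move is a 1.1-fold lower number from compound 2 to compound 3 (0.02 log units; within the scatter) on this estimate. For compound 3 the estimate is 180 nM with an expected range from 70 nM to 450 nM in this read-out.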

Compound 3, half-maximal inhibitory concentration: 3400 nM
Compound 3: middle estimate off by 19-fold (1.28 log units), on the low side; measured number above the stated range.
By their numbers in this assay, from the lowest: compound 2; then compound 1; then compound 3.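

In this assay, (hydroxycarbamoyl)methyl in place of hydroxycarbamoyl on a saturated chain carbon, six bonds along the chain from an oxygen on an aromatic ring, gives an 18-fold higher number from compound 2 to compound 3 (1.25 log units; beyond the scatter) and is a large step, so this single chain extension alone is enough to weaken inhibition markedly. With that same chain held constant, hydrogen in place of 1H-benzimidazol-2-yl on an aromatic carbon gives a 2.1-fold higher number from compound 1 to compound 3 (0.33 log units; beyond the scatter) as a modest step, which shows that this position on the core also affects the read-out. Nothing available explains either step.

From the compounds shown here alone, whether the number keeps rising with 2-(hydroxycarbamoyl)ethyl or with a still longer chain remains open. Also open, going by these compounds, are whether 1H-benzimidazol-2-yl has the same effect on the shorter chain of compound 2, and how a carboxylic acid in place of hydroxycarbamoyl would read.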